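A hydroxymethyl added to compound 2

The compounds below may be only part of what the source reports. "The series", "measured", "known", "first", "only" and "open" are said of these compounds alone.

For the measured compounds named here, in an ADME assay on microsomes from liver (Homo sapiens) for metabolic stability, with a stated time of 10 min (a lower number here means that less of the compound is left, a higher number that more of the compound is left), compound 2 `O=C(C1CCS(=O)(=O)CC1)N1CC[C@](c2ccc(C(F)(C(F)(F)F)C(F)(F)F)cc2)(S(=O)(=O)c2ccc(F)cc2)C1` gives 93%, its only number and close to the top of the scale. Compound 1 `O=C(O)C1CCC(O)(C(=O)N2CC[C@](c3ccc(C(F)(C(F)(F)F)C(F)(F)F)cc3)(S(=O)(=O)c3ccc(F)cc3)C2)CC1` has two entries, given in the several entries of compound 1 in this assay, 100%; 95% (2 entries), and compound 1 gives 100%; 95% (2 entries), within the usual scatter of compound 2.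

Compound 3 `O=C(N1CC[C@](c2ccc(C(F)(C(F)(F)F)C(F)(F)F)cc2)(S(=O)(=O)c2ccc(F)cc2)C1)C1(CO)CCS(=O)(=O)CC1` differs from compound 2 in one place: hydroxymethyl in place of hydrogen on a saturated ring carbon. This is hydroxymethyl in place of hydrogen on a saturated ring carbon, three ring bonds from the ring sulfur. Going by the values given here, no measured pair shows this change, so the expectation is a cautious one. With compound 2 at 93%, little room remains upward. The expected step of a number 3 percentage points lower from compound 2 to compound 3 (within the scatter) is small and slightly downward, within the usual scatter of this assay. The estimate for compound 3 is 90%, with an expected range from 76% to 100%.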

Compound 3, percent of the compound remaining: 75%
Compound 3: middle estimate off by 15 percentage points, on the high side; the whole stated range lies above it.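

In this assay, the ring carbon three ring bonds from the ring sulfur turns out to be sensitive to change: hydroxymethyl in place of hydrogen there gives a number 18 percentage points lower from compound 2 to compound 3 (beyond the scatter). Compound 2 showed only that the plain 1,1-dioxothian-4-yl group goes with a high reading, while this pair shows that adding just 2 heavy atoms at this carbon can lower the amount of compound left. Nothing shown here explains why the reading falls.

On these data alone, what remains open is whether the step comes from the hydroxyl of the hydroxymethyl group or from having any group at this carbon. A methyl group at the same place would help separate those two readings, and a longer chain such as hydroxyethyl, or an amine, would show how far the effect extends.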